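This account rests on a few compounds, and the source may have more. Where it says the series, first, only, none or still open, it means among the compounds named here.

Of the compounds shown here, three have so far been measured in an ADME assay on MT4 cells (Homo sapiens) for cytotoxicity, with a stated time of 5 days; a higher number here means that more compound is tolerated, a lower number that less compound is tolerated. Compound 1, `CC(C)(C)C#Cc1cc(N(C(=O)[C@H]2CC[C@H](C)CC2)[C@H]2CC[C@@](O)(CO[C@H]3CCOC3)CC2)c(C(=O)O)s1`, gives 18100 nM. Compound 2, `CC(C)(C)C#Cc1cc(N(C(=O)[C@H]2CC[C@H](C)CC2)[C@H]2CC[C@H](OC3CCOC3)CC2)c(C(=O)O)s1`, gives 3070 nM. Compound 3, `CC(C)(C)C#Cc1cc(N(C(=O)[C@H]2CC[C@H](C)CC2)[C@H]2CC[C@H](OC3CCOCC3)CC2)c(C(=O)O)s1`, gives 1990 nM, which is the lowest of the three numbers, meaning the least compound tolerated. Compound 3 sits closest to compound 2, and the gap to compound 1 is the widest in the set. Among the compounds with values here, the one step recorded between neighbours, a 1.5-fold lower number from compound 2 to compound 3 (0.19 log units; within the scatter), swaps one saturated oxygen-containing ring for another and stays within the scatter.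

Compound 4, `CC(C)(C)C#Cc1cc(N(C(=O)[C@H]2CC[C@H](C)CC2)[C@H]2CC[C@H](Oc3ccncn3)CC2)c(C(=O)O)s1`, comes next. pyrimidin-4-yl in place of oxan-4-yl on an oxygen on a saturated carbon This is a different kind of change from the recorded step: a saturated ring leaves and an aromatic ring enters at the same place. Within the data shown here, no measured pair shows such a swap, so the only guide is that the earlier change at this oxygen, a 1.5-fold lower number from compound 2 to compound 3 (0.19 log units; within the scatter), stayed within the scatter. Compound 4 is therefore expected to land near compound 3. For compound 4 the expected step is a 1.0-fold higher number from compound 3 to compound 4 (0.00 log units; within the scatter), not beyond the scatter. In this assay compound 4 is estimated at 2000 nM, with a range from 700 nM to 6000 nM.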

Compound 4, half-maximal cytotoxic concentration: 599 nM
Compound 4: the middle estimate sits 3.3-fold (0.52 log units) above what was measured, and the stated range ends above it.
By their numbers in this assay, from the lowest: compound 4; then compounds 3 and 2 (each within the scatter of the next); then compound 1.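

In this assay, this position no longer looks indifferent to the group it carries: pyrimidin-4-yl in place of oxan-4-yl on an oxygen on a saturated carbon gives a 3.3-fold lower number from compound 3 to compound 4 (0.52 log units; beyond the scatter), and pyrimidin-4-yl in place of oxolan-3-yl gives a 5.1-fold lower number from compound 2 to compound 4 (0.71 log units; beyond the scatter), so less compound is tolerated after either swap. The swap between the two saturated rings gave only a 1.5-fold lower number from compound 2 to compound 3 (0.19 log units; within the scatter), so the change from a saturated ring to an aromatic one is what first moves the number past the scatter here, even though oxan-4-yl and pyrimidin-4-yl hold the same count of heavy atoms. Nothing measured here explains why the number falls.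

The compounds shown cannot separate the aromatic ring itself from its ring nitrogens, since both arrive together in pyrimidin-4-yl, and a plain phenyl ring on the same oxygen would pull the two apart. Going by these compounds, it also remains open how this position would respond to an open chain, such as 2-methoxyethyl, in place of any ring.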